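The source may report more compounds than this note shows. Statements on the series, on what has been measured and on what is new or still open speak of the compounds shown alone.

Measured in an ADME assay on BHK-21 cells (Mesocricetus auratus) for cytotoxicity, read by MTT assay, with a stated time of 72 h; a lower number here means that less compound is tolerated, a higher number that more compound is tolerated:
- compound 1 `Cc1cccc(C2CC(c3ccc(Oc4ccccc4)cc3)=NN2c2ccc(S(N)(=O)=O)cc2)c1` gives 8000 nM
- compound 2 `NS(=O)(=O)c1ccc(N2N=C(c3ccc(OCc4ccccc4)cc3)CC2c2ccccc2Cl)cc1` gives 12000 nM
- compound 3 `NS(=O)(=O)c1ccc(N2N=C(c3ccc(OCc4ccccc4)cc3)CC2c2ccc(Cl)cc2)cc1` gives 15000 nM

A higher number here means that more compound is tolerated, but repeated measurements naturally scatter. Compound 2, at 12000 nM in this assay, lies within that scatter of both compound 1 and compound 3, so these three numbers cannot be ranked.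

The unmeasured compound 4 `NS(=O)(=O)c1ccc(N2N=C(c3ccc(Oc4ccccc4)cc3)CC2c2ccccc2Cl)cc1` differs from compound 2 in one place. It has phenyl in place of benzyl on an oxygen on an aromatic ring, so benzyloxy becomes phenoxy.

Going by the values given here, the only measured step between two close relatives is a 1.3-fold higher number from compound 2 to compound 3 (0.10 log units; within the scatter), and it concerns a different place, a chlorophenyl group on a saturated ring carbon. It therefore gives only indirect guidance. Compound 1 offers a second clue: it already carries phenoxy, alongside a different group on a saturated ring carbon, and gives 8000 nM, which is within the scatter of the two benzyloxy compounds.

No step beyond the scatter is therefore expected in this assay, and the expected change is a 1.2-fold lower number from compound 2 to compound 4 (0.08 log units; within the scatter) in size and direction. Compound 4 is estimated at 10000 nM, with an expected range of 5500 nM to 18000 nM for the measurement.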

Compound 4, half-maximal cytotoxic concentration: 8000 nM
Compound 4: middle estimate off by 1.3-fold (0.10 log units), on the high side; low and high end bracket the measured number.
By their numbers in this assay, from the lowest: compounds 1, 4, 2 and 3 (each within the scatter of the next).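

In this assay, the change from benzyloxy to phenoxy can now be read directly, with 2-chlorophenyl held constant on the saturated ring carbon: the step is a 1.5-fold lower number from compound 2 to compound 4 (0.18 log units; within the scatter). The group on the saturated ring carbon can also now be read with phenoxy held constant, where 2-chlorophenyl in place of 3-methylphenyl gives no change at the digits printed from compound 1 to compound 4 (within the scatter), so neither replacement moves this cytotoxicity read-out beyond the usual scatter in these pairs. No measured evidence is available to explain either result.

The compounds shown leave open whether the result for this oxygen substituent would hold with a group that has no aromatic ring, such as a methyl group, a longer alkyl chain or a chain ending in an amine. They also leave open whether phenoxy in place of benzyloxy would give a similar result with the 4-chlorophenyl group of compound 3, since a single matched pair cannot show whether a step carries over to another part of the series.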